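Cytotoxicity of Three Amide Variants and an Untested Fourth

A few compounds are considered here, and "the series" means these few. Any claim that something is new, unique, unknown or untested is made for them only; others in the source may bear on it.

Measured in an ADME assay on MT4 cells (Homo sapiens) for cytotoxicity, read by MTT assay; on this read-out lower numbers stand for higher toxicity in this test and higher numbers for lower toxicity in this test:
Compound 1 `Cc1cc(C)cc(S(=O)(=O)c2c(C(=O)NCc3cccc(N)c3)[nH]c3ccc(Cl)cc23)c1` gives > 53400 nM, a limit of the test.
Compound 2 `Cc1cc(C)cc(S(=O)(=O)c2c(C(=O)NCC(=O)NCc3ccco3)[nH]c3ccc(Cl)cc23)c1` gives > 50000 nM, also a limit.
Compound 3 `Cc1cc(C)cc(S(=O)(=O)c2c(C(=O)NC(C)C(=O)NC(C)c3ccccc3)[nH]c3ccc(Cl)cc23)c1` gives 21700 nM.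

Compound 1 thus stands at a limit, and of the other two values one more is a limit, so only compound 3 has a number. The change to compound 4 `Cc1cc(C)cc(S(=O)(=O)c2c(C(=O)NC(C)C(=O)NCc3ccncn3)[nH]c3ccc(Cl)cc23)c1` is a group of 12 heavy atoms (8 carbon, 3 nitrogen, 1 oxygen; one six-membered aromatic ring with 2 hetero atoms) in place of a group of 8 heavy atoms (7 carbon, 1 nitrogen; one six-membered aromatic ring of carbon only), on an amide-type nitrogen. For the measured compounds named here, the single measured step, a step that the two limits leave unreadable from compound 1 to compound 2, cannot be sized because the limit of > 50000 nM in this assay, at which 1 of the 3 values shown sits, and the limit of > 53400 nM in this assay, at which 1 of the 3 values shown sits, cap both of its ends. Going by the values given here, no measured step therefore bears directly on this change, and compound 3, the one compound with a number, lies close to those limits. Compound 4 is expected to give 50000 nM, within 20000 nM to 120000 nM. The expected step is an at least 1.0-fold lower number from compound 1 to compound 4 (0.02 log units; that floor lies within the scatter), not beyond the scatter.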

Compound 4, half-maximal cytotoxic concentration: 28100 nM
Compound 4: middle estimate off by 1.8-fold (0.25 log units), on the high side; the measured number falls inside the stated range.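

In this assay, compound 4 and compound 3 cannot be told apart, with a 1.3-fold higher number from compound 3 to compound 4 (0.11 log units; within the scatter) for (pyrimidin-4-yl)methyl in place of 1-phenylethyl on the amide-type nitrogen. Compound 1 and compound 2 each carry only a limit of the test, so the other steps are floors: an at least 1.9-fold lower number from compound 1 to compound 4 (0.27 log units; that floor lies within the scatter) and an at least 1.7-fold lower number from compound 2 to compound 4 (0.25 log units; that floor lies within the scatter). A six-membered aromatic ring with 2 hetero atoms at this place thus gives a readable number rather than a limit.

As far as these compounds go, whether a morpholine or a carboxylic acid on this nitrogen would shift the number beyond the scatter stays open. From the compounds shown here alone, the true distance from compound 1 and compound 2 to compound 4 also stays open.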